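Diethylamino in place of (cyclopentylmethyl)amino: compound 3 to compound 4

The compounds below may be only part of what the source reports. "The series", "measured", "known", "first", "only" and "open" are said of these compounds alone.

Compound 1 `CC(C)Nc1ccc(NC(=O)c2cc(Cl)ccc2O)c(Cl)c1` gives 11000 nM
Compound 2 `O=C(Nc1ccc(NCC2CC2)cc1Cl)c1cc(Cl)ccc1O` gives 14400 nM
Compound 3 `O=C(Nc1ccc(NCC2CCCC2)cc1Cl)c1cc(Cl)ccc1O` gives 21500 nM

In an ADME assay on A549 cells (Homo sapiens) for cytotoxicity, read by resazurin assay, with a stated time of 48 h (a lower number here means that less compound is tolerated, a higher number that more compound is tolerated), compound 3 gives 21500 nM and is not separated from either of the other two compounds beyond the scatter. Its two measured steps are a 2.0-fold higher number from compound 1 to compound 3 (0.29 log units; within the scatter) and a 1.5-fold higher number from compound 2 to compound 3 (0.17 log units; within the scatter) while the remaining step is a 1.3-fold higher number from compound 1 to compound 2 (0.12 log units; within the scatter) and the three values therefore form a single group.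

Compound 4 `CCN(CC)c1ccc(NC(=O)c2cc(Cl)ccc2O)c(Cl)c1` has not yet been measured. It carries diethylamino in place of (cyclopentylmethyl)amino on an aromatic carbon and the rest of the structure stays the same. All three measured steps change the group on this same nitrogen, so they bear on the new step. None of them takes away a hydrogen-bond donor, however, and the data show nothing about that part of the change.

The expectation rests on the largest of the three, the step of a 2.0-fold higher number from compound 1 to compound 3 (0.29 log units; within the scatter) and no step beyond the scatter is therefore expected in this assay in either direction. The expected step is a 1.4-fold lower number from compound 3 to compound 4 (0.16 log units; within the scatter) and it is only an estimate. For compound 4 the estimated value is 15000 nM with an expected range from 7000 nM to 32000 nM in this assay.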

Compound 4, half-maximal cytotoxic concentration: 55500 nM
Compound 4: middle estimate off by 3.7-fold (0.57 log units), on the low side, outside the stated range (above it).
By their numbers in this assay, from the lowest: compounds 1, 2 and 3 (each within the scatter of the next); then compound 4.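

In this assay the diethylamino group of compound 4 separates from the other three compounds, which stay within the scatter of one another, with a 2.6-fold higher number from compound 3 to compound 4 (0.41 log units; beyond the scatter) and a 3.9-fold higher number from compound 2 to compound 4 (0.59 log units; beyond the scatter) and also a 5.0-fold higher number from compound 1 to compound 4 (0.70 log units; beyond the scatter) all lying beyond the scatter. The separation does not follow the ring, since isopropylamino in compound 1 has no ring either and still gives the largest of these steps; among these four compounds it goes instead with the loss of the hydrogen-bond donor on this nitrogen, a change that the earlier steps did not include. With only compound 4 lacking that donor, this is a single observation that cannot be separated from the other features of diethylamino, and no measurement shown gives a reason for the step.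

The compounds shown leave open whether another group without a hydrogen on this nitrogen, such as dimethylamino or a pyrrolidine ring, would fall with compound 4 or with the other three. They also leave open whether a methoxy group, with oxygen in place of the nitrogen, would give a similar result.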